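Swapping a Cyclopropyl Amide for an Azide

The compounds below may be only part of what the source reports. "The series", "measured", "known", "first", "only" and "open" are said of these compounds alone.

Three amides built on one shared core have been tested in a functional assay on KYSE-450 cells (Homo sapiens) for inhibition, read by MTT assay, with a stated time of 48 h; a lower number here means a stronger inhibitor, a higher number a weaker inhibitor. Compound 1 `COc1ccc(CN(C(=O)C2CC2)c2cc(OC)c(OC)c(OC)c2)cc1O` gives 80 nM, the lowest of the three numbers. Compound 3 `C/C=C/C(=O)N(Cc1ccc(OC)c([N+](=O)[O-])c1)c1cc(OC)c(OC)c(OC)c1` gives 510 nM, and compound 2 `C/C=C/C(=O)N(Cc1cc(OC)c(OC)c(OC)c1)c1ccc(OC)c(O)c1` gives 9160 nM, so compound 1 stands clearly apart from both on the numbers alone, while the structural differences to those two are not followed here.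

The next compound keeps the core of compound 1 and changes only the acyl group. Compound 4 `COc1ccc(CN(C(=O)CN=[N+]=[N-])c2cc(OC)c(OC)c(OC)c2)cc1O` carries azidomethyl in place of cyclopropyl on a carbonyl carbon. Going by the values given here, nothing measured so far tells how this assay responds to that change, since no pair of measured compounds differs in just this way. The cyclopropyl ring of compound 1 gives way to a chain with no ring and one added hydrogen-bond acceptor, and with no guide from the data a modest weakening is expected rather than a gain, a step from compound 1 to compound 4 of a 2.5-fold higher number from compound 1 to compound 4 (0.40 log units; beyond the scatter). Compound 4 is therefore expected to give about 200 nM, in a range from 60 nM to 700 nM.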

Compound 4, half-maximal inhibitory concentration: 160 nM
Compound 4: middle estimate off by 1.3-fold (0.10 log units), on the high side; the measured number falls inside the stated range.
By their numbers in this assay, from the lowest: compounds 1 and 4 (each within the scatter of the next); then compound 3; then compound 2.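

In this assay, putting azidomethyl in place of cyclopropyl on a carbonyl carbon gives a 2.0-fold higher number from compound 1 to compound 4 (0.30 log units; within the scatter), so the two compounds cannot be told apart. Going by these compounds alone, this is the first direct reading at this position: the three-membered ring can leave, and a chain with no ring and one hydrogen-bond acceptor can enter, with no step beyond the scatter. Nothing at hand measures any property of these two groups, so the data offer no explanation of this result.

On these data alone, this single pair cannot show how far the position stretches, so it remains open whether an aminomethyl group, a carboxylic acid or a longer carbon chain on the same carbonyl carbon would keep the number in this range. As far as these compounds go, it is equally open whether the same swap would read alike on a different core.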